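Swapping dimethylamino for 5-methyl-1,2,4-oxadiazol-3-yl on the shared core

This account rests on a few compounds, and the source may have more. Where it says the series, first, only, none or still open, it means among the compounds named here.

Three compounds share one core and differ in a single group on an aromatic carbon: compound 1 `COC(=O)N[C@H](C(=O)NN(CCC[C@@](O)(Cc1ccccc1)C(=O)N[C@H]1c2ccccc2C[C@H]1O)Cc1ccc(Cl)cc1)C(C)(C)C` carries chloro, compound 2 `COC(=O)N[C@H](C(=O)NN(CCC[C@@](O)(Cc1ccccc1)C(=O)N[C@H]1c2ccccc2C[C@H]1O)Cc1ccc(Br)cc1)C(C)(C)C` bromo and compound 3 `COC(=O)N[C@H](C(=O)NN(CCC[C@@](O)(Cc1ccccc1)C(=O)N[C@H]1c2ccccc2C[C@H]1O)Cc1ccc(N(C)C)cc1)C(C)(C)C` dimethylamino. In an ADME assay on MT4 cells (Homo sapiens) for cytotoxicity (a lower number here means that less compound is tolerated, a higher number that more compound is tolerated), compound 1 reads > 10000 nM as a limit, not a number. Compound 2 reads > 10000 nM as a limit too. Compound 3 reads > 10000 nM as a limit as well, so no number places it. The data so far amount to the limit of > 10000 nM in this assay, at which 3 of the 3 values shown sit, and nothing more.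

The change to compound 4 `COC(=O)N[C@H](C(=O)NN(CCC[C@@](O)(Cc1ccccc1)C(=O)N[C@H]1c2ccccc2C[C@H]1O)Cc1ccc(-c2noc(C)n2)cc1)C(C)(C)C` is 5-methyl-1,2,4-oxadiazol-3-yl in place of dimethylamino on an aromatic carbon with the rest of the structure the same. Within the data shown here, the steps that bear on it, a step that the two limits leave unreadable from compound 1 to compound 3 and a step that the two limits leave unreadable from compound 2 to compound 3 and a step that the two limits leave unreadable from compound 1 to compound 2 at the same place, have no readable size. Compound 3 remains the anchor at the limit of > 10000 nM and on that ground no step beyond the scatter is expected, in either direction. The estimated step is a step that the limit leaves unreadable from compound 3 to compound 4 in this assay and another reading as a limit is the likeliest outcome. Compound 4 is expected at 20000 nM with an estimated range from 8000 nM to 50000 nM as its span.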

Compound 4, half-maximal cytotoxic concentration: > 10000 nM
Compound 4: only a limit was reported; the forecaster's own chance of this, stated with the estimate: 80%; the middle value is on the limit's open side.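

In this assay compound 4 gives > 10000 nM, a limit and not a number, so its steps from compound 1, compound 2 and compound 3 cannot be read. The compounds shown leave open at what concentration any of them turns cytotoxic, and the data stop at a single reading: the limit of > 10000 nM in this assay, at which 4 of the 4 values shown sit.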